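A few compounds are considered here, and "the series" means these few. Any claim that something is new, unique, unknown or untested is made for them only; others in the source may bear on it.

Measured compounds:
compound 1 `Cc1ccc(C(=O)N2N=C(c3cc4ccccc4oc3=O)CC2c2ccccc2)cc1`: 13200 nM
compound 2 `O=c1oc2ccccc2cc1C1=NN(S(=O)(=O)c2ccc([N+](=O)[O-])cc2)C(c2ccccc2)C1`: 46600 nM

Both compounds were tested in a functional assay on PC-3 cells (Homo sapiens) for cytotoxicity, read by MTT assay, with a stated time of 48 h; a higher number here means a weaker inhibitor, a lower number a stronger inhibitor. Compound 1 gives 13200 nM. Compound 2 gives 46600 nM, the higher of the two numbers, and the gap to compound 1 is beyond the usual scatter. For the measured compounds named here, no step between the measured compounds can be isolated, since compound 1 and compound 2 differ in more than one place.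

Compound 3 `Cc1ccc(S(=O)(=O)N2N=C(c3cc4ccccc4oc3=O)CC2c2ccccc2)cc1` is not yet measured in this assay. It is derived from compound 2 by methyl in place of nitro on an aromatic carbon. Going by the values given here, no measured pair isolates this exchange, so the expectation rests only on the two values shown. Compound 1, which also carries a methyl group on its phenyl ring, gives 13200 nM, a lower number than compound 2 at 46600 nM. Compound 1 also differs from compound 2 in the linking group, so the gap between them does not isolate the methyl for nitro exchange. A modest lowering of the number, possibly not beyond the scatter, is expected. Compound 3 is therefore estimated at 25000 nM, within 8000 nM to 80000 nM. The expected step is a 1.9-fold lower number from compound 2 to compound 3 (0.27 log units; within the scatter).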

Compound 3, half-maximal inhibitory concentration: 48600 nM
The estimate for compound 3 lay 1.9-fold (0.29 log units) below the measured number, within the range that was stated.
By their numbers in this assay, from the lowest: compound 1; then compounds 2 and 3 (each within the scatter of the next).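

Working notes on the series: in this assay, methyl in place of nitro on an aromatic carbon, para to a large group, gives a 1.0-fold higher number from compound 2 to compound 3 (0.02 log units; within the scatter) and so, with the sulfonyl link held constant, the 4-nitrophenyl to 4-methylphenyl exchange leaves the number unmoved beyond the scatter. With the 4-methylphenyl group held constant, the link can now be read on its own: (4-methylphenyl)sulfonyl in place of (4-methylphenyl)carbonyl on the amine nitrogen in the ring gives a 3.7-fold higher number from compound 1 to compound 3 (0.57 log units; beyond the scatter) and is the only step in this set that lies beyond the scatter, so among these three compounds the separation of compound 1 follows the link and not the group on the phenyl ring. No measurement at hand accounts for the size of either step.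

Still open, from the compounds shown here alone, is whether this flat response at the para position extends beyond nitro and methyl to other groups, such as an amine or a carboxylic acid. Also open, going by these compounds, is whether the same exchange gives a similarly flat result with the carbonyl link of compound 1, and so whether the two places act independently.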